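Swapping ethoxy for fluoro on a weakly cytotoxic scaffold

A few compounds are considered here, and "the series" means these few. Any claim that something is new, unique, unknown or untested is made for them only; others in the source may bear on it.

Measured so far:
compound 1 `Clc1cccc2sc(Nc3nc4ccccc4s3)nc12`: > 50000 nM
compound 2 `CCOc1ccc2nc(NC(=S)Nc3ccccc3)sc2c1`: 43800 nM

Of the compounds shown here, two have been tested in a functional assay on THP-1 cells (Homo sapiens) for cytotoxicity, read by MTT assay, with a stated time of 48 h; on this read-out higher numbers stand for weaker inhibition and lower numbers for stronger inhibition. Compound 1 `Clc1cccc2sc(Nc3nc4ccccc4s3)nc12` returns only a limit of the assay, > 50000 nM, and not a number. Compound 2 `CCOc1ccc2nc(NC(=S)Nc3ccccc3)sc2c1` gives 43800 nM in this assay, the only number shown. Compound 1 alone sits at a limit, a point summarised by the limit of > 50000 nM in this assay, at which 1 of the 2 values shown sits. Among the compounds with values here, compound 2 therefore stands as the one compound with a measured value, and that value speaks of weak inhibition.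

Compound 3 `Fc1ccc2nc(NC(=S)Nc3ccccc3)sc2c1` differs from compound 2 in one place: fluoro in place of ethoxy on an aromatic carbon. Within the data shown here, no measured step of this kind is available, so the direction of any change is unknown. The expected step of a 1.1-fold lower number from compound 2 to compound 3 (0.04 log units; within the scatter) in this assay is small, not beyond the usual scatter. Compound 3 is expected to give 40000 nM in this assay, within a range of 15000 nM to 100000 nM.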

Compound 3, half-maximal inhibitory concentration: 46600 nM
Compound 3: the middle estimate sits 1.2-fold (0.07 log units) below what was measured, within the range that was stated.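

In this assay, within the data shown here, fluoro in place of ethoxy on this aromatic carbon gives a 1.1-fold higher number from compound 2 to compound 3 (0.03 log units; within the scatter), the first measured step at this position. Removing the ethoxy group with its hydrogen-bond acceptor and placing a single fluorine atom there therefore shifts the cytotoxicity reading by no more than repeated measurements of one compound might. Compound 1 sits at a limit of the assay and gives no number: the limit of > 50000 nM in this assay, at which 1 of the 3 values shown sits.

Going by these compounds, what an amine, a carboxylic acid or a longer chain such as butoxy would do on this same carbon stays open, and so does whether any group here can bring the number clearly down. Among these compounds, this single step covers only two groups at one place, so it says nothing about changes elsewhere on the shared core.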